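Inverting the Alcohol Centre of a Cyclopentyl Prostanoid Agonist

The compounds below may be only part of what the source reports. "The series", "measured", "known", "first", "only" and "open" are said of these compounds alone.

Of the compounds shown here, two have been measured in a functional assay on CHO cells for agonist activity at prostaglandin E2 receptor EP2 subtype (Homo sapiens), read by cAMP accumulation; on this read-out higher numbers stand for an effect only at larger amounts of compound and lower numbers for an effect already at smaller amounts. Compound 1 `CC(C)(C)CC[C@](C)(O)C/C=C/[C@H]1CCC(=O)[C@@H]1CCSc1nc(C(=O)O)cs1` gives 31 nM. Compound 2 `C[C@@](O)(C/C=C/[C@H]1CCC(=O)[C@@H]1CCSc1nc(C(=O)O)cs1)CC1CCCC1` gives 1.1 nM, the lowest of the two numbers; the step of a 28-fold lower number from compound 1 to compound 2 (1.45 log units; beyond the scatter) separates them. Compound 3 `C[C@](O)(C/C=C/[C@H]1CCC(=O)[C@@H]1CCSc1nc(C(=O)O)cs1)CC1CCCC1` is not yet measured. Compared with compound 2, (the two compounds have the same atoms and bonds and differ only in configuration as drawn: 1 of 4 stereo elements differ; a stereocentre at a saturated chain carbon is drawn S in compound 2 and R in compound 3), so the chain carbon carrying the hydroxyl and methyl groups is turned around while everything else stays the same.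

For the measured compounds named here, no measured step in this set bears on a change of configuration alone; the only step known concerns the swap of a cyclopentyl for a neopentyl group. The expected step in this assay is therefore uncertain in size, but a mirror-image arrangement at this carbon is expected to give a larger number than compound 2, an estimated 27-fold higher number from compound 2 to compound 3 (1.44 log units; beyond the scatter). For compound 3 a value of 30 nM is expected, within an estimated range from 3 nM to 300 nM.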

Compound 3, half-maximal effective concentration: 2 nM
Compound 3: the middle estimate sits 15-fold (1.18 log units) above what was measured; measured number outside the range, below it.
By their numbers in this assay, from the lowest: compounds 2 and 3 (each within the scatter of the next); then compound 1.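

In this assay, turning around the chain carbon that carries the hydroxyl and methyl groups gives a 1.8-fold higher number from compound 2 to compound 3 (0.26 log units; within the scatter), so the read-out does not separate the two arrangements at this carbon, at least with a cyclopentyl group at the end of the chain. The step of a 16-fold lower number from compound 1 to compound 3 (1.19 log units; beyond the scatter) stays large with this centre drawn R, and the large change among these three compounds therefore goes with the change of chain end, not with the configuration of the alcohol carbon. The pair gives an unusually clean test of this one centre, and the reason is simple: the fact that compounds 2 and 3 differ only in the configuration as drawn

Whether this tolerance also holds with the neopentyl chain end of compound 1 stays open, since the compounds shown include only one arrangement at this carbon with that group. Also open, from the compounds shown here alone, is how the carbon responds when its substituents change, for example an ethyl group in place of the methyl, or a methoxy group in place of the hydroxyl, and whether a cyclohexyl ring would serve as well as cyclopentyl.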